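A few compounds are considered here, and "the series" means these few. Any claim that something is new, unique, unknown or untested is made for them only; others in the source may bear on it.

In an assay on HEK293 cells for binding affinity to 5-hydroxytryptamine receptor 7 (Homo sapiens), read by radioligand binding, tested at 1 uM (on this read-out higher numbers stand for more inhibition at the one concentration tested (going by the name of the read-out) and lower numbers for less inhibition), compound 2 `CCc1ccc2ccn(CCN3CCCN(C)CC3)c2c1` gives 66%. For the measured compounds named here, this is the lower of the two numbers measured so far: compound 1 `CN1CCCN(CCn2ccc3ccc(C(F)(F)F)cc32)CC1` gives 89% in this assay, and the step of a number 23 percentage points lower from compound 1 to compound 2 (beyond the scatter) lies beyond the scatter. Compound 3 `C=C(C)c1ccc2ccn(CCN3CCCN(C)CC3)c2c1` is yet to be measured; it differs from compound 2 by 1-methylethenyl in place of ethyl on an aromatic carbon. Going by the values given here, the one measured step, trifluoromethyl to ethyl, concerns a different exchange at the same position and so bears only loosely on this one; it shows that the group at this aromatic carbon can move the number by a modest amount. Among the compounds with values here, with no step that matches the present change, the expected step of a number 1 percentage points lower from compound 2 to compound 3 (within the scatter) is taken as small, within or near the scatter, in no firm direction. Compound 3 is therefore estimated at 65% in this assay, with a range from 45% to 82%.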

Compound 3, a percentage reported as inhibition, at one concentration (the size of the read-out at that concentration, not a potency): 72%
Estimate against measurement, compound 3: 7 percentage points below; the range from low to high includes it.
By their numbers in this assay, from the lowest: compounds 2 and 3 (each within the scatter of the next); then compound 1.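

In this assay, the step to 1-methylethenyl in place of ethyl on this aromatic carbon gives a number 6 percentage points higher from compound 2 to compound 3 (within the scatter), so on this read-out the added carbon and the double bond outside aromatic rings leave the two compounds indistinguishable. Trifluoromethyl stays apart from this new group as well, with a number 17 percentage points lower from compound 1 to compound 3 (beyond the scatter), and so compound 1 is now separated from both of the hydrocarbon-bearing compounds rather than from ethyl alone. Nothing available here accounts for these numbers.

The compounds shown leave open whether a chlorine, a methoxy group or an amine on this carbon would stand with trifluoromethyl or with the two hydrocarbon groups. They also leave open whether a longer chain, such as propyl or butyl, would still give a number within the scatter of ethyl.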